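The source may hold more compounds than are shown below. What is called first, only, known or untested is meant among the compounds shown, and "the series" means these compounds.

Compound 2 `CCCC(=O)OCSc1ccccc1C(=O)NCC(=O)OC` is the less tolerated of the two measured compounds: in an ADME assay on CEM-SS cells (Homo sapiens) for cytotoxicity, read by XTT assay, with a stated time of 6 days (a higher number here means that more compound is tolerated, a lower number that less compound is tolerated), compound 2 gives 27.3 uM, whereas compound 1 `CCCC(=O)OCSc1ccccc1C(=O)N[C@@H]1CCC[C@@H]1C(N)=O` gives 90 uM in this assay. For the measured compounds named here, the single measured step, a 3.3-fold lower number from compound 1 to compound 2 (0.52 log units; beyond the scatter), is the only comparison available. Compound 3 `CCCC(=O)OCSc1ccccc1C(=O)NCC(=O)NCC(N)=O` differs from compound 2 by (carbamoylmethyl)amino in place of methoxy on a carbonyl carbon. That change reintroduces a carbamoyl group of the kind present in compound 1, and the step of a 3.3-fold lower number from compound 1 to compound 2 (0.52 log units; beyond the scatter) is the nearest guide, though it concerns a different part of the molecule. A move back toward higher tolerance is therefore expected, but of modest size and with considerable uncertainty, so the expected step is a 1.6-fold higher number from compound 2 to compound 3 (0.22 log units; within the scatter). Compound 3 is estimated to give 45 uM in this assay. The estimated range for compound 3 runs from 20 uM to 110 uM.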

Compound 3, half-maximal toxic concentration: > 100 uM
Compound 3: only a limit was reported (the forecaster's own chance of this, stated with the estimate: 15%); middle value at least 2.2-fold (0.34 log units) from the limit.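

At this carbonyl carbon, (carbamoylmethyl)amino in place of methoxy gives an at least 3.6-fold higher number from compound 2 to compound 3 (0.56 log units; beyond the scatter) in this assay, so tolerance of the compound responds to what sits here. The reading for compound 3 is a limit of the assay and not a number, which makes this step a floor: the limit of > 100 uM in this assay, at which 1 of the 3 values shown sits. Setting ((carbamoylmethyl)carbamoyl)methyl in place of 2-carbamoylcyclopentyl on the amide-type nitrogen gives an at least 1.1-fold higher number from compound 1 to compound 3 (0.04 log units; that floor lies within the scatter), so the open chain reaches the tolerance of the cyclopentyl compound, though no order between the two can be claimed.

On these data alone, how far past the limit compound 3 lies stays open, as does what the carbamoyl contributes apart from the rest of the entering group. As far as these compounds go, whether a carboxylic acid, a methylamino group or a longer chain on this carbonyl carbon would behave alike also remains open.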